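Benzyl Ether to Thiophenylmethyl Ether on a Fluorinated Amino Acid Core

This account rests on a few compounds, and the source may have more. Where it says the series, first, only, none or still open, it means among the compounds named here.

Measured so far:
compound 1 `N[C@]1(C(=O)O)[C@H]2[C@@H](C[C@H]1OCc1ccccc1)[C@]2(F)C(=O)O`, 7.14 nM
compound 2 `N[C@]1(C(=O)O)[C@H]2[C@@H](C[C@H]1OCc1cc(Cl)c(Cl)c(Cl)c1)[C@]2(F)C(=O)O`, 3.67 nM
compound 3 `N[C@]1(C(=O)O)[C@H]2[C@@H](C[C@H]1OCc1c(F)c(F)c(F)c(F)c1F)[C@]2(F)C(=O)O`, 3.77 nM

In an assay on CHO cells for binding affinity to metabotropic glutamate receptor 2 (Rattus norvegicus) (a higher number here means a weaker inhibitor, a lower number a stronger inhibitor), compound 1 gives 7.14 nM, the highest of the three numbers; its gaps to compound 3 and to compound 2 are both within the usual scatter, so the three compounds sit together. Compound 4 `N[C@]1(C(=O)O)[C@H]2[C@@H](C[C@H]1OCc1cccs1)[C@]2(F)C(=O)O` has not yet been measured. It differs from compound 1 in one place: thiophen-2-yl in place of phenyl on a saturated chain carbon bound to an oxygen on a saturated carbon. Within the data shown here, no measured pair shows a step of this kind, so nothing in the data points in either direction. The estimated step from compound 1 to compound 4 in this assay is a 1.1-fold lower number from compound 1 to compound 4 (0.04 log units; within the scatter), which is not expected to exceed the scatter. Compound 4 is therefore estimated at 6.5 nM, in the range 2.5 nM to 17 nM.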

Compound 4, inhibition constant: 8.79 nM
Beside the measured number, compound 4's estimate is 1.4-fold (0.13 log units) below it; measured number inside the range.
By their numbers in this assay, from the lowest: compounds 2, 3, 1 and 4 (each within the scatter of the next, the first and the last beyond it).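

Among these compounds, measured in this assay the replacement of phenyl by thiophen-2-yl on a saturated chain carbon bound to an oxygen on a saturated carbon gives a 1.2-fold higher number from compound 1 to compound 4 (0.09 log units; within the scatter) and is the first one-place step at this position. It shows that a five-membered aromatic ring with a sulfur atom can take the place of the six-membered carbon ring with no change beyond the scatter. Nothing at hand bears on this result. The compounds shown leave open how thiophen-3-yl, furan-2-yl or a pyridine ring would read here, and whether a chlorine or a methyl group on the thiophene ring would move the number.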